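A few compounds are considered here, and "the series" means these few. Any claim that something is new, unique, unknown or untested is made for them only; others in the source may bear on it.

Measured in a functional assay on the whole organism for inhibition, with Rattus norvegicus as the target; on this read-out lower numbers stand for an effect already at smaller amounts and higher numbers for an effect only at larger amounts of compound:
Compound 1 `CCCCc1ncc(/C=C(\Cc2cccs2)C(=O)O)n1Cc1ccc(C(=O)O)cc1Cl`: 2.4 mg/kg
Compound 2 `CCCCc1ncc(/C=C(\Cc2cccs2)C(=O)O)n1Cc1ccc(C(=O)O)c(Cl)c1`: 16 mg/kg

Compound 2 has the higher of the two numbers, so a larger amount of it is needed for the effect. Compound 3 `CCCCc1ncc(/C=C(\Cc2cccs2)C(=O)O)n1Cc1ccc(C(=O)O)c(Cl)c1Cl`, not yet measured, differs from compound 2 by one substitution: chloro in place of hydrogen on an aromatic carbon. In words, chloro takes the place of hydrogen on an aromatic carbon.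

Within the data shown here, only one measured step bears on this change. Compound 1 and compound 2 differ in where the chloro group sits on the ring bearing the carboxy group, and a 6.7-fold higher number from compound 1 to compound 2 (0.82 log units; beyond the scatter) is beyond the scatter. Among the measured compounds shown here, compound 3 carries the chloro group of compound 2 and also the one found in compound 1, which gives 2.4 mg/kg. For the measured compounds named here, a move towards the lower number is therefore expected, though probably not all the way, since no measured compound holds two chloro groups and their combined result in this assay is unknown.

The expected step is a 2.7-fold lower number from compound 2 to compound 3 (0.43 log units; beyond the scatter). For compound 3 the estimated value is 6 mg/kg, with an expected range of 2 mg/kg to 18 mg/kg.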

Compound 3, dose for 50% inhibition: 5.4 mg/kg
Beside the measured number, compound 3's estimate is 1.1-fold (0.05 log units) above it; measured number inside the range.
By their numbers in this assay, from the lowest: compound 1; then compound 3; then compound 2.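

In this assay the added chloro group, ortho to a chloro group and meta to a carboxy group, gives a 3.0-fold lower number from compound 2 to compound 3 (0.47 log units; beyond the scatter) and so shows that this position on the ring can take a substituent with a gain on this read-out, which a comparison of the two single chloro isomers could not show. The same compound read from the other side gives a 2.3-fold higher number from compound 1 to compound 3 (0.35 log units; beyond the scatter), so a second chloro group does not act in one direction: it lowers the number from one single chloro compound and raises it from the other, and the dichloro compound 3 falls between the two in the order of these three compounds. No measurement here accounts for either step, and nothing explains why the two chloro groups together land where they do.

On these data alone, it remains open whether a fluoro, methyl or methoxy group in place of this added chloro group would give a step of the same direction and size. Also open, as far as these compounds go, is whether the step would hold with an amide in place of the carboxy group on this ring, or with a longer chain on the shared core.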